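The compounds below may be only part of what the source reports. "The series", "measured", "known", "first", "only" and "open" are said of these compounds alone.

Compound 2 `COc1ccccc1CNC(=O)CSc1cn(C)c2ccccc12` and compound 1 `Cn1cc(SCC(=O)NCc2ccc(Cl)c(Cl)c2)c2ccccc21` share one core and differ in a single place: 3,4-dichlorophenyl in place of 2-methoxyphenyl on a saturated chain carbon bound to an amide-type nitrogen. In an ADME assay on HEK-293T cells (Homo sapiens) for cytotoxicity, read by CCK-8 assay, with a stated time of 24 h (on this read-out higher numbers stand for lower toxicity in this test and lower numbers for higher toxicity in this test), compound 2 gives > 100000 nM, which is a limit of the assay and not a number. In this assay compound 1 gives > 100000 nM, again a limit. The step that the two limits leave unreadable from compound 2 to compound 1 therefore cannot be sized. Compound 3 `COc1ccccc1CNC(=O)CSc1c[nH]c2cc(Br)ccc12` carries a different core; the difference between the two cores is not broken down here. In this assay compound 3 gives > 100000 nM, also a limit. All three measured values sit at the limit of > 100000 nM in this assay, at which 3 of the 3 values shown sit. Compound 4 `O=C(CSc1c[nH]c2cc(Br)ccc12)NCc1ccc(Cl)c(Cl)c1` is not yet measured and differs from compound 3 by the same change: 3,4-dichlorophenyl in place of 2-methoxyphenyl on a saturated chain carbon bound to an amide-type nitrogen. Because the limit of > 100000 nM in this assay, at which 3 of the 3 values shown sit, holds for every measured compound, the step from compound 3 to compound 4 is expected to remain unreadable, a step that the limit leaves unreadable from compound 3 to compound 4. Compound 4 is estimated at 150000 nM in this assay.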

Compound 4, half-maximal cytotoxic concentration: 67600 nM
The estimate for compound 4 lay 2.2-fold (0.35 log units) above the measured number; measured number inside the range.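

In this assay, among the compounds shown here, the change to 3,4-dichlorophenyl gives an at least 1.4-fold lower number from compound 3 to compound 4 (0.17 log units; that floor lies within the scatter), and compound 4 is the only compound here with a readable number. On the core of compound 2 the same change leaves a step that cannot be read, so the data do not show whether the change acts alike on the two cores. The true size of the change stays hidden on both cores, since only a floor is known on one and nothing on the other: the limit of > 100000 nM in this assay, at which 3 of the 4 values shown sit.

The compounds shown leave open how an amine or a carboxylic acid on the ring in place of the chlorines would read in this assay. They also leave open what a longer chain on the amide-type nitrogen would do.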